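A few compounds are considered here, and "the series" means these few. Any claim that something is new, unique, unknown or untested is made for them only; others in the source may bear on it.

Notes on the series. Compound 1 `O=c1c2cnn(-c3ccc(F)cc3)c2ncn1CC1(O)CCN(Cc2ccccc2)CC1` is the reference point, but in an assay on Sf21 cells for inhibition of ubiquitin carboxyl-terminal hydrolase 7 (Homo sapiens), read by spectrophotometry, with stated times of 30 min and 2 h (on this read-out higher numbers stand for weaker inhibition and lower numbers for stronger inhibition), compound 1 stands at "not determined" (no result reported), so no number anchors it. Among the compounds with values here, compound 2 `O=c1c2cnn(-c3ccc(F)cc3)c2ncn1CC1(O)CCN(Cc2ccccc2Cl)CC1` is the only measured member; in this assay compound 2 gives 3400 nM. Compound 3 `O=c1c2cnn(-c3ccc(F)cc3)c2ncn1CC1(O)CCN(Cc2ccc(F)cc2Cl)CC1` is unmeasured. Relative to compound 1 it carries 2-chloro-4-fluorophenyl in place of phenyl on a saturated chain carbon bound to an amine nitrogen in a ring. Within the data shown here, no step between two measured compounds exists in this set, so the size of the move from compound 1 to compound 3 in this assay cannot be read from data; the working expectation is a shift no larger than the usual scatter, with no direction claimed. Among the measured compounds shown here, the only anchor is compound 2, which gives 3400 nM in this assay, and compound 3 is taken to sit in the same region. Compound 3 is therefore expected near 3000 nM, with a range of 1000 nM to 10000 nM.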

Compound 3, half-maximal inhibitory concentration: 1600 nM
Compound 3: middle estimate off by 1.9-fold (0.27 log units), on the high side; measured number inside the range.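

Fluoro in place of hydrogen on an aromatic carbon gives a 2.1-fold lower number from compound 2 to compound 3 (0.33 log units; beyond the scatter) in this assay, a modest change but one beyond the scatter, and the first step in this set that can be read. It shows that the number in this assay responds to a small substitution on the aromatic ring of the group on the ring amine nitrogen, with the lower number standing for stronger inhibition. No measurement bearing on the reason for this shift is available.

With no number for compound 1, the contribution of the chloro group and the full move from benzyl to 2-chloro-4-fluorobenzyl cannot be read. As far as these compounds go, whether a nitrile or a methoxy group in place of the fluoro would lower the number further, match it or raise it remains open.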